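The source may hold more compounds than are shown below. What is called first, only, known or untested is meant among the compounds shown, and "the series" means these compounds.

Compound 1 `CNC(=O)/C=C/c1ccncc1-c1ccc2ccccc2c1`: > 10000 nM
Compound 2 `O=C(CCc1ccncc1-c1ccc2ccccc2c1)N1CCOCC1`: > 10000 nM

Both entries come from a functional assay on KB cells (Homo sapiens) for inhibition, read by sulforhodamine B assay, with a stated time of 72 h; on this read-out lower numbers stand for stronger inhibition of growth and higher numbers for weaker inhibition of growth. For compound 1 the entry > 10000 nM is a limit of the assay and not a number. For compound 2 the entry > 10000 nM is likewise a limit. Within the data shown here, compound 1 therefore stands at the limit of > 10000 nM in this assay, at which 2 of the 2 values shown sit, and no step between two measured compounds can be drawn; the two entries show only that neither compound reached a measurable level of growth inhibition.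

The compound still to be measured is compound 3 `CN(C)C(=O)/C=C/c1ccncc1-c1ccc2ccccc2c1`. It differs from compound 1 in one place: methyl in place of hydrogen on an amide-type nitrogen. Among the measured compounds shown here, no measured step of this kind is available, so the expectation rests on compound 1 alone. The step that the limit leaves unreadable from compound 1 to compound 3 is expected to stay within the scatter, with no clear direction. Compound 3 is thus expected to give about 20000 nM in this assay, within 5000 nM to 80000 nM, most probably again only as a limit.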

Compound 3, concentration for 50% growth inhibition: 7760 nM
Beside the measured number, compound 3's estimate is 2.6-fold (0.41 log units) above it; measured number inside the range.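

In this assay compound 3 gives 7760 nM, the only true number among the compounds shown, so with a second methyl on this amide-type nitrogen the growth inhibition can be read at all. Changing methylcarbamoyl to dimethylcarbamoyl gives an at least 1.2-fold lower number from compound 1 to compound 3 (0.11 log units; that floor lies within the scatter); this is only a floor, so the true size of the step could be small or large, and the change cannot yet be called a real improvement. Readable values remain the exception in this small set: the limit of > 10000 nM in this assay, at which 2 of the 3 values shown sit.

Still open, as far as these compounds go, is whether a larger group on this nitrogen, such as ethyl, would move the number clearly beyond the scatter. Also open, from the compounds shown here alone, is how a primary amide, with two hydrogens on the nitrogen, or a carboxylic acid in place of the amide would behave.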